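Swapping Nitro for Trifluoromethoxy on Compound 1

A few compounds are considered here, and "the series" means these few. Any claim that something is new, unique, unknown or untested is made for them only; others in the source may bear on it.

In an ADME assay on HEK293 cells (Homo sapiens) for cytotoxicity, with a stated time of 72 h (a higher number here means that more compound is needed for the effect, a lower number that less compound is needed), compound 1 (`Cc1cc(NC(=O)Nc2cccc([N+](=O)[O-])c2)c2ccccc2n1`) gives > 25000 nM, which is a limit and not a number. Compound 2 (`Cc1cc(NC(=O)Nc2ccccc2C(C)(C)C)c2ccccc2n1`) gives > 25000 nM, also a limit. Compound 3 (`Cc1cc(NC(=O)Nc2ccc(C(=O)O)c(O)c2)c2ccccc2n1`) gives > 25000 nM, again a limit. Compound 1 therefore has no exact position, and the picture is simply the limit of > 25000 nM in this assay, at which 3 of the 3 values shown sit, for now. Compound 4 (`Cc1cc(NC(=O)Nc2cccc(OC(F)(F)F)c2)c2ccccc2n1`) carries trifluoromethoxy in place of nitro on an aromatic carbon. Among the measured compounds shown here, no measured pair shows what such a change does, so the expectation rests only on the limit of > 25000 nM in this assay, at which 3 of the 3 values shown sit, across these relatives. The expected step of a number no higher from compound 1 to compound 4 (the limit leaves the size open) stays within the usual scatter. Compound 4 is estimated at 25000 nM in this assay, with an expected range from 10000 nM to 50000 nM here.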

Compound 4, half-maximal effective concentration: 22000 nM
Beside the measured number, compound 4's estimate is 1.1-fold (0.06 log units) above it; the measured number falls inside the stated range.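

Trifluoromethoxy in place of nitro, meta to a large group, gives an at least 1.1-fold lower number from compound 1 to compound 4 (0.05 log units; that floor lies within the scatter) in this assay. This step is only a floor, so the change may be small or larger, but the floor alone shows no real shift. Compound 4 is the only compound shown with an exact number rather than a limit: the limit of > 25000 nM in this assay, at which 3 of the 4 values shown sit.

On these data alone, how far compound 1 truly lies from compound 4 stays open. So does what an amine or a carboxylic acid would give on this aromatic carbon.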